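Swapping Methyl for Dichloro on the Benzyl Arm

The source may hold more compounds than are shown below. What is called first, only, known or untested is meant among the compounds shown, and "the series" means these compounds.

Of the compounds shown here, three sharing one core have been measured in a functional assay on ECa-109 cells (Homo sapiens) for inhibition, read by MTT assay, with a stated time of 72 h; on this read-out lower numbers stand for stronger inhibition and higher numbers for weaker inhibition. Compound 1 `Cc1ccc(Cn2cc(CSC(=S)N3CCN(C(=O)OC(C)(C)C)CC3)nn2)cc1` gives 47900 nM. Compound 2 `Cc1ccc(Cn2cc(CSC(=S)N3CCN(C(=O)OCc4ccccc4)CC3)nn2)cc1` gives 32600 nM, and compound 3 `Cc1ccc(-n2cc(CSC(=S)N3CCN(C(=O)OC(C)(C)C)CC3)nn2)cc1` gives 114000 nM. Compound 2 thus shows the lowest of the three numbers; compound 1 sits within the scatter of it, whereas compound 3 lies beyond it. The two measured steps are a 1.5-fold lower number from compound 1 to compound 2 (0.17 log units; within the scatter), a change of the carbamate ester, and a 2.4-fold higher number from compound 1 to compound 3 (0.38 log units; beyond the scatter), a change of the group on the aromatic nitrogen.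

Compound 4 `O=C(OCc1ccccc1)N1CCN(C(=S)SCc2cn(Cc3ccc(Cl)c(Cl)c3)nn2)CC1` differs from compound 2 by 3,4-dichlorophenyl in place of 4-methylphenyl on a saturated chain carbon bound to an aromatic nitrogen. Within the data shown here, no measured step alters the substituents on this ring; the step from compound 1 to compound 3 touches the same region but changes the link to the nitrogen, not the ring itself, so the data give no direct guide. Compound 4 is therefore expected to show no step beyond the scatter, a 1.1-fold lower number from compound 2 to compound 4 (0.04 log units; within the scatter). Compound 4 is estimated at 30000 nM, with a range from 10000 nM to 90000 nM.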

Compound 4, half-maximal inhibitory concentration: 29400 nM
Compound 4: the middle estimate sits 1.0-fold (0.01 log units) above what was measured, and the stated range covers the measured number.
By their numbers in this assay, from the lowest: compounds 4, 2 and 1 (each within the scatter of the next); then compound 3.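

In this assay, among these compounds, the first change to the substituents on this ring, 3,4-dichlorophenyl in place of 4-methylphenyl on a saturated chain carbon bound to an aromatic nitrogen, gives a 1.1-fold lower number from compound 2 to compound 4 (0.04 log units; within the scatter), so the assay does not separate the two compounds. For this pair, then, exchanging the methyl group for two chlorine atoms leaves the number within the usual scatter, whereas the earlier step at this end of the molecule changed the link to the nitrogen rather than the ring. No measured evidence bearing on this result is available to explain it.

Still open, from the compounds shown here alone, is how this ring would read with a methoxy group or an amine on it. Also open, going by these compounds, is whether the same swap would read alike in compound 1, which carries the tert-butyl ester.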